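Trimming a Chain Methyl and Cell Tolerance

The compounds below may be only part of what the source reports. "The series", "measured", "known", "first", "only" and "open" are said of these compounds alone.

Compound 1 `CCCC(CCOc1ccc(-c2ccc(Cl)cc2)cc1)CCN1CCN(c2ccncc2)C1=O` is a chain-linked molecule in which a branched saturated chain joins an aromatic ether to a ring that carries an amide-type nitrogen. In an ADME assay on cells (Homo sapiens) for cytotoxicity (a higher number here means that more compound is tolerated, a lower number that less compound is tolerated), compound 1 gives > 25000 nM; this is a limit of the assay, not a measured number. Compound 2 `CC(C)(CCOc1ccc(-c2ccc(Cl)cc2)cc1)CCN1CCN(c2ccncc2)C1=O` shares the same core and differs only in how the chain is branched. In this assay compound 2 gives > 25000 nM, which is again a limit. Both measurements therefore land at the limit of > 25000 nM in this assay, at which 2 of the 2 values shown sit, so neither compound shows measurable harm to the cells up to the highest concentration tested.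

Compound 3 `CCC(CCOc1ccc(-c2ccc(Cl)cc2)cc1)CCN1CCN(c2ccncc2)C1=O` has not been measured. It differs from compound 1 by hydrogen in place of methyl on a saturated chain carbon, five bonds along the chain from an amide-type nitrogen in a ring and an oxygen on an aromatic ring. Going by the values given here, no measured pair shows this exact change. With the chain only shortened by a single carbon, the expectation is that compound 3 will behave like compound 1 and stay beyond the reach of the assay, because compound 1 itself gives > 25000 nM. The step is expected to be a step that the limit leaves unreadable from compound 1 to compound 3, nothing beyond the usual scatter. Compound 3 is thus estimated at 30000 nM, within a range of 15000 nM to 60000 nM.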

Compound 3, half-maximal cytotoxic concentration: > 25000 nM
Compound 3 gave a limit, no number; the forecaster's own chance of this, stated with the estimate: 85%; the middle value is on the limit's open side.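

Going by these compounds alone, compound 3, like compound 1, sits at a limit of this assay rather than at a number, so no step between compound 1 and compound 3 can be read. The compounds shown leave open at what concentration, if any, harm to the cells would appear, and whether swapping methyl for hydrogen changes that: the limit of > 25000 nM in this assay, at which 3 of the 3 values shown sit.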